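Series notes: the step from compound 1 to compound 3

The source may hold more compounds than are shown below. What is called first, only, known or untested is meant among the compounds shown, and "the series" means these compounds.

compound 1 `CCCOC(=O)c1ccc(NC(=O)c2cccc(-c3cc(C(=O)Nc4ccncc4F)ccc3CN)c2)cc1`: > 2 h (a limit)
compound 2 `CCC(C)OC(=O)c1cccc(NC(=O)c2cccc(-c3cc(C(=O)Nc4ccncc4F)ccc3CN)c2)c1`: 0.267 h

In an ADME assay on a cell-free system (plasma, Homo sapiens) for metabolic stability, read by LC-MS (on this read-out higher numbers stand for a longer-lived compound and lower numbers for a shorter-lived compound), compound 1 stands at > 2 h, which is a limit of the assay and not a number. Compound 2 gives a measured number, 0.267 h. Compound 3 `NCc1ccc(C(=O)Nc2ccncc2F)cc1-c1cccc(C(=O)Nc2cccc(C(=O)O)c2F)c1` has not yet been measured. Its difference from compound 1 is 3-carboxy-2-fluorophenyl in place of 4-(propoxycarbonyl)phenyl on an amide-type nitrogen. For the measured compounds named here, no measured step covers this change. The expected step that the limit leaves unreadable from compound 1 to compound 3 in this assay stays within the scatter, with any movement toward a longer half-life. This expectation rests on compound 1 and its > 2 h, again a limit. Compound 3 is estimated at 3 h, with an expected range of 1 h to 6 h.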

Compound 3, half-life: > 2 h
Compound 3 gave a limit, no number; the forecaster's own chance of this, stated with the estimate: 75%; the middle value is on the limit's open side.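

For the compounds shown here, compound 1 and compound 3 both end at a limit of the assay rather than a number, so no step between them can be read: the limit of > 2 h in this assay, at which 2 of the 3 values shown sit.
Still open, going by these compounds, is whether 3-carboxy-2-fluorophenyl in place of 4-(propoxycarbonyl)phenyl on an amide-type nitrogen changes the half-life at all, and by how much.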